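The compounds below may be only part of what the source reports. "The series", "measured", "known", "first", "only" and "open" are said of these compounds alone.

Compound 1 `Cc1ccc(-c2nnc(Nc3csc(-c4ccccc4)c3)s2)cc1` is the measured starting point here. In a functional assay on U-373MG ATCC cells (Homo sapiens) for inhibition, read by colorimetric assay and MTT assay, with a stated time of 72 h (on this read-out higher numbers stand for weaker inhibition and lower numbers for stronger inhibition), compound 1 gives > 100000 nM, and this is a limit of the test, the edge of what it can report, not a number. Compound 2 `Cc1ccc(-c2cc(Nc3nnc(-c4ccc(C)cc4)s3)cs2)cc1` carries in this assay the entry "not determined" (no result reported), so no figure exists for it either. Compound 1 thus stands alone, and the only mark of where it lies is the limit of > 100000 nM in this assay, at which 1 of the 2 values shown sits. Compound 3 `COc1ccc(-c2nnc(Nc3csc(-c4ccccc4)c3)s2)cc1` differs from compound 1 in one spot: methoxy in place of methyl on an aromatic carbon, or read one bond further out, 4-methylphenyl to 4-methoxyphenyl. Among the compounds with values here, no pair of measured compounds shows a step of this kind, so there is nothing to lean on; the change is a small one in what is counted, and the expected step is from compound 1 to compound 3 of about a number no higher from compound 1 to compound 3 (the limit leaves the size open), which is no movement beyond the scatter of repeated measurements. Compound 3 is therefore estimated at 100000 nM in this assay, with a likely range from 30000 nM to 300000 nM, and the test will most probably again report only a limit.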

Compound 3, half-maximal inhibitory concentration: 92000 nM
The estimate for compound 3 lay 1.1-fold (0.04 log units) above the measured number; the range from low to high includes it.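

In this assay compound 3 gives 92000 nM, the first single number among the compounds shown, and it still stands for very weak inhibition. Methoxy in place of methyl on an aromatic carbon, para to a large group, comes to an at least 1.0-fold lower number from compound 1 to compound 3 (0.03 log units; that floor lies within the scatter), so the result gives no sign that this swap changes the read-out by more than repeated measurements would. The true size of the step stays unknown because the reading for compound 1 stops at the edge of what the test can report: the limit of > 100000 nM in this assay, at which 1 of the 3 values shown sits.

Going by these compounds, only methyl and methoxy have been seen at this position, so it remains open whether a quite different group there, such as an amine or a carboxylic acid, would bring the number down clearly. On these data alone, it also remains open whether changes elsewhere on the shared core would do more than this swap, since the two compounds that can be compared differ only at this one spot.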